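Aryl variation on the shared core: towards compound 4

The source may hold more compounds than are shown below. What is called first, only, known or untested is meant among the compounds shown, and "the series" means these compounds.

Measured so far in a functional assay on KB cells (Homo sapiens) for antiproliferative activity, read by sulforhodamine B assay, with a stated time of 3 days; on this read-out lower numbers stand for an effect already at smaller amounts and higher numbers for an effect only at larger amounts of compound:
compound 1, `CCC1=C(O)c2c(oc(-c3ccc(CC)cc3)cc2=O)C(CC)(CC)C1=O`: 21.9 uM
compound 2, `CCC1=C(O)c2c(oc(-c3ccc(C(C)C)cc3)cc2=O)C(CC)(CC)C1=O`: 8.13 uM
compound 3, `CCOc1ccc(-c2cc(=O)c3c(o2)C(CC)(CC)C(=O)C(CC)=C3O)cc1`: > 52.4 uM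

Compound 1 stands with the higher of the two numbers given; its nearest neighbour is compound 2, reached by a 2.7-fold lower number from compound 1 to compound 2 (0.43 log units; beyond the scatter), where methyl replaces hydrogen on the saturated chain carbon bound to the aromatic carbon. For compound 3 the read-out stops at the limit of > 52.4 uM in this assay, at which 1 of the 3 values shown sits, so compound 3 gives a limit and not a number. Against compound 1 this is an at least 2.3-fold higher number from compound 1 to compound 3 (0.37 log units; beyond the scatter), ethoxy in place of ethyl on an aromatic carbon, and against compound 2 it is an at least 6.4-fold higher number from compound 2 to compound 3 (0.80 log units; beyond the scatter).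

Compound 4, `CCC1=C(O)c2c(oc(-c3cccc(F)c3)cc2=O)C(CC)(CC)C1=O`, differs from compound 1 by 3-fluorophenyl in place of 4-ethylphenyl on an aromatic carbon. The measured steps all vary the group on the aryl ring: the larger isopropyl lowers the number, the ethoxy pushes it to the limit. The 3-fluorophenyl carries no such alkyl, so the step of a 1.6-fold higher number from compound 1 to compound 4 (0.20 log units; within the scatter) is expected to run upward, at least modest and possibly reaching the limit. For compound 4 the estimate is 35 uM, within 12 uM to 80 uM.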

Compound 4, concentration for half-maximal effect: > 56.2 uM
Compound 4 was reported as a limit; the forecaster's own chance of this, stated with the estimate: 30%; middle value at least 1.6-fold (0.20 log units) away from the limit.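

With 3-fluorophenyl on the aromatic carbon next to the ring oxygen, compound 4 gives a limit and not a number in this assay: the limit of > 56.2 uM in this assay, at which 1 of the 4 values shown sits.

Against the two compounds with an alkyl group on the aryl ring, the change gives an at least 2.5-fold higher number from compound 1 to compound 4 (0.40 log units; beyond the scatter) and an at least 6.9-fold higher number from compound 2 to compound 4 (0.83 log units; beyond the scatter), so the loss of a readable number is no longer tied to the ethoxy of compound 3 alone and also follows a change that leaves no alkyl or ethoxy group on the aryl ring.

Among the four compounds, numbers now stand only for 4-ethylphenyl in compound 1 and 4-isopropylphenyl in compound 2, while the step between compound 3 and compound 4 cannot be read, since both are limits.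

The step to compound 4 changes two things at once, the loss of the 4-ethyl group and the entry of fluorine at another ring position, and the compounds shown do not separate them. Plain phenyl, 4-fluorophenyl and 3-ethylphenyl would each separate these two changes, and 4-tert-butylphenyl would show whether the trend from ethyl to isopropyl continues.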